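This account rests on a few compounds, and the source may have more. Where it says the series, first, only, none or still open, it means among the compounds named here.

Three compounds have been measured so far in an ADME assay on microsomes from liver (Mus musculus) for metabolic stability, read by LC-MS, with a stated time of 60 min, tested at 1 uM; on this read-out higher numbers stand for a longer-lived compound and lower numbers for a shorter-lived compound:

compound 1, `Cc1cnc2[nH]c(N3CCN(c4ccc(C)c(Cl)c4)CC3)nc2c1`, gives 0.133 h
compound 2, `N#Cc1cnc(NC(=O)N2CCN(c3ccc(Cl)c(Cl)c3)CC2)s1`, gives 1.95 h
compound 3, `Cc1cc(NC2CCN(C(=O)Nc3ncc(Cl)s3)C2)ccc1Cl`, gives 0.183 h

Of these three, compound 2 stands at the top. Its nearest neighbour on the read-out is compound 3, whose number is lower by a gap that lies beyond the usual scatter, and the furthest is compound 1, whose number is lower still. Within the data shown here, compound 2 is thus the longest-lived of the three, and the two other compounds are not simply variants of it, so none of the measured pairs sets a precedent for the change that follows.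

The next compound, compound 4 `N#Cc1cnc(NC(=O)N2CCN(c3cnc(Cl)c(Cl)c3)CC2)s1`, differs from compound 2 in a single place: 5,6-dichloropyridin-3-yl in place of 3,4-dichlorophenyl on an amine nitrogen in a ring

Among the measured compounds shown here, no pair of measured compounds shares this change, so its size cannot be read off the numbers in hand. The step of a 1.1-fold lower number from compound 2 to compound 4 (0.03 log units; within the scatter) is expected to be none beyond the scatter. The estimate leans on compound 2 because compound 2 itself gives 1.95 h with the same core around the altered group. Compound 4 is therefore estimated at 1.8 h, with a range from 0.7 h to 4.5 h.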

Compound 4, half-life in the Mus musculus assay: 1.33 h
Estimate against measurement, compound 4: 1.4-fold (0.13 log units) above, and the stated range covers the measured number.
By their numbers in the Mus musculus assay, from the lowest: compounds 1 and 3 (each within the scatter of the next); then compounds 4 and 2 (each within the scatter of the next).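

Among these compounds, in the Mus musculus assay, the first matched pair at this position shows a 1.5-fold lower number from compound 2 to compound 4 (0.17 log units; within the scatter), so on this core, 5,6-dichloropyridin-3-yl on an amine nitrogen in a ring can stand in place of 3,4-dichlorophenyl with no difference in half-life beyond repeat-to-repeat scatter. In a physicochemical assay for solubility, read by nephelometry, at pH 2 (on this read-out lower numbers stand for lower solubility and higher numbers for higher solubility), compound 2 gives < 1600 nM, which is a limit of the assay and not a number. In the physicochemical assay, compound 4 gives < 1600 nM, which is likewise a limit of the assay.

The step in solubility from compound 2 to compound 4 cannot be read, and whether this change alters solubility at all stays open, because both compounds sit at the same limit: the limit of < 1600 nM in the physicochemical assay, at which 2 of the 2 values shown sit.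
Among the compounds shown here, also open is how half-life and solubility would respond if the ring at this position carried an amine or a carboxylic acid instead of its two chlorines, since this single pair covers only one change at one position on one core.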